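The compounds below may be only part of what the source reports. "The series", "measured", "known", "first", "only" and "open" are said of these compounds alone.

Measured compounds, with their values in a functional assay on MCF7 cells (Homo sapiens) for cytotoxicity, read by MTT assay, with a stated time of 48 h; on this read-out higher numbers stand for weaker inhibition and lower numbers for stronger inhibition:
Compound 1 `N#Cc1ccc(CN(C(=O)Nc2cc(C(F)(F)F)cc(C(F)(F)F)c2)n2cnnc2)cc1` gives 7220 nM.
Compound 2 `COc1ccc(OC)c(CN(C(=O)Nc2ccc(C)cc2)n2cnnc2)c1` gives a limit of > 50000 nM.
Compound 3 `COc1ccc(CN(C(=O)Nc2ccc(Cl)c(C(F)(F)F)c2)n2cnnc2)cc1OC` gives a limit of > 50000 nM.

Compound 2 stands at the limit of > 50000 nM in this assay, at which 2 of the 3 values shown sit, so for compound 2 no number is known, only that limit. Going by the values given here, compound 1 is the one measured compound with an actual number. The unmeasured compound 4 `CCCCCCCCCNC(=O)N(Cc1cc(OC)ccc1OC)n1cnnc1` differs from compound 2 in one place: nonyl in place of 4-methylphenyl on an amide-type nitrogen. Among the compounds with values here, no step between two measured compounds has been computed, so the size that such a change brings in this assay cannot be read from these data. Compound 2 sits at a limit, and a step toward weaker inhibition could not appear there as a number. The step from compound 2 to compound 4 is expected to be an at least 1.1-fold lower number from compound 2 to compound 4 (0.04 log units; that floor lies within the scatter), which is meant as no change beyond the scatter, with the chance of a number appearing at all judged roughly even. Compound 4 is therefore expected to give about 45000 nM, with a range from 12000 nM to 50000 nM.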

Compound 4, half-maximal inhibitory concentration: > 50000 nM
Compound 4 ended at the assay's limit; the forecaster's own chance of this, stated with the estimate: 55%; middle value at least 1.1-fold (0.04 log units) from the limit.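

Compound 2 and compound 4 both end at a limit of this assay, so nonyl in place of 4-methylphenyl gives no readable step, because neither compound has an actual number: the limit of > 50000 nM in this assay, at which 3 of the 4 values shown sit. The compounds shown leave open what nonyl in place of 4-methylphenyl does where a number can be read.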